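A few compounds are considered here, and "the series" means these few. Any claim that something is new, unique, unknown or untested is made for them only; others in the source may bear on it.

Compound 1, `CCN(CC)S(=O)(=O)c1ccc(S(=O)(=O)N2CCC[C@@H](C(=O)NC3CN(C(=O)C4CC4)C3)C2)cc1`: 2800 nM
Compound 2, `CCOC(=O)[C@@H]1CCCN(S(=O)(=O)c2ccc(S(=O)(=O)N(CC)C(C)C)cc2)C1`: 1000 nM
Compound 3, `CCOC(=O)[C@@H]1CCCN(S(=O)(=O)c2ccc(S(=N)(=O)N(CC)CC)cc2)C1`: 2600 nM

In a functional assay on MIA PaCa-2 cells (Homo sapiens) for inhibition, read by MTT assay, with a stated time of 7 days (a higher number here means a weaker inhibitor, a lower number a stronger inhibitor), compound 3 gives 2600 nM, the second highest of the three numbers. Its nearest neighbour is compound 1, which gives 2800 nM, within the scatter of compound 3. Going by the values given here, the furthest is compound 2, which gives 1000 nM; the one measured step, a 2.6-fold higher number from compound 2 to compound 3 (0.41 log units; beyond the scatter), is modest but beyond the scatter.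

Compound 4, `CCOC(=O)[C@@H]1CCCN(S(=O)(=O)c2ccc(S(=O)(=O)N3CCCCC3)cc2)C1`, differs from compound 3 in one place: a group of 9 heavy atoms (5 carbon, 1 nitrogen, 2 oxygen, 1 sulfur; one six-membered non-aromatic ring with 1 hetero atom) in place of a group of 8 heavy atoms (4 carbon, 2 nitrogen, 1 oxygen, 1 sulfur; no ring), on an aromatic carbon. The group that leaves in this change is the same group that entered in the step from compound 2 to compound 3, so that step is the only one that bears here, and it ran toward a higher number. Reversing that group, now in favour of a ring-bearing group of comparable size, is therefore expected to run the other way, toward a lower number, though the ring itself has no measured precedent among these compounds. Compound 4 is thus expected to show a step of a 2.0-fold lower number from compound 3 to compound 4 (0.30 log units; within the scatter) in this assay. Compound 4 is estimated at 1300 nM, with a range from 500 nM to 3500 nM.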

Compound 4, half-maximal inhibitory concentration: 2900 nM
Beside the measured number, compound 4's estimate is 2.2-fold (0.35 log units) below it; low and high end bracket the measured number.
By their numbers in this assay, from the lowest: compound 2; then compounds 3, 1 and 4 (each within the scatter of the next).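

In this assay, placing (piperidin-1-yl)sulfonyl on this aromatic carbon, para to a large group, gives a 1.1-fold higher number from compound 3 to compound 4 (0.05 log units; within the scatter), so the ring-bearing group and the group it replaces cannot be told apart here. On the sulfonyl sulfur, piperidin-1-yl in place of ethyl(isopropyl)amino gives a 2.9-fold higher number from compound 2 to compound 4 (0.46 log units; beyond the scatter), and with a 2.6-fold higher number from compound 2 to compound 3 (0.41 log units; beyond the scatter) this leaves compound 2 with the lower number in both one-place comparisons at this position, so its ethyl(isopropyl)amino group stands apart from the two replacements. Nothing given here explains why these steps differ in size.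

The compounds shown leave open whether pyrrolidin-1-yl or morpholin-4-yl on the sulfonyl sulfur would stay with compound 4 or come closer to compound 2. They also leave open what the ethyl ester contributes on its own: compound 1 differs from each of the others in more than one place, and a diethylamino group on the sulfonyl sulfur of the ester series would be needed to link it to them.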